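Reshaping the five-carbon group on the ring nitrogen

The source may hold more compounds than are shown below. What is called first, only, known or untested is meant among the compounds shown, and "the series" means these compounds.

- compound 1 `CC(C)n1ccnc1/C=C/C(=O)/C=C/c1coc2ccccc2c1=O`: 1200 nM
- compound 2 `CC(C)CCn1ccnc1/C=C/C(=O)/C=C/c1coc2ccccc2c1=O`: 4000 nM

In a functional assay on LNCaP cells (Homo sapiens) for inhibition, read by WST assay, with a stated time of 3 days (a higher number here means a weaker inhibitor, a lower number a stronger inhibitor), compound 2 is the weaker of the two measured inhibitors, with the higher number, 4000 nM. Compound 3 `CCC(CC)n1ccnc1/C=C/C(=O)/C=C/c1coc2ccccc2c1=O` keeps the shared core and changes one group: pentan-3-yl in place of isopentyl on an aromatic nitrogen. Among the measured compounds shown here, only one measured step bears on this change: isopentyl in place of isopropyl, a 3.3-fold higher number from compound 1 to compound 2 (0.52 log units; beyond the scatter), which is modest but beyond the scatter. Pentan-3-yl resembles the isopropyl of compound 1, at 1200 nM, in branching at the carbon bound to the nitrogen, so part of that step may be reversed. A small fall in the number is therefore expected, a 2.0-fold lower number from compound 2 to compound 3 (0.30 log units; within the scatter), although a single step is thin evidence. For compound 3 the estimated value is 2000 nM, with an expected range from 800 nM to 5000 nM.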

Compound 3, half-maximal inhibitory concentration: 2800 nM
For compound 3 the middle estimate is 1.4-fold (0.15 log units) below the measured one; the measured number falls inside the stated range.
By their numbers in this assay, from the lowest: compound 1; then compounds 3 and 2 (each within the scatter of the next).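

In this assay, rearranging the same five carbons from isopentyl into pentan-3-yl gives a 1.4-fold lower number from compound 2 to compound 3 (0.15 log units; within the scatter), so this change of shape does not separate the two groups. Pentan-3-yl shares with isopropyl the branch at the carbon bound to the nitrogen, yet that shared branch does not bring the number back to the level of compound 1, as the step shows: a 2.3-fold higher number from compound 1 to compound 3 (0.37 log units; beyond the scatter). Among these three compounds, the isopropyl of compound 1 therefore stands apart from both five-carbon groups, whether or not they branch at that carbon.

Going by these compounds, how a smaller methyl, a ring such as cyclopentyl, or a chain ending in an amine would behave at this nitrogen remains open. Nothing available here explains why these numbers differ.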